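A few compounds are considered here, and "the series" means these few. Any claim that something is new, unique, unknown or untested is made for them only; others in the source may bear on it.

Compound 1 `CC1=CCC[C@](C)(CC/C(C)=C/CC2=C(O)C(=O)C=C(N[C@H](C(=O)O)[C@@H](C)O)C2=O)[C@@H]1C`: > 10 ug/mL
Compound 2 `C=C1[C@H](C)CCC[C@]1(C)CC/C(C)=C/CC1=C(O)C(=O)C=C(N[C@H](C(=O)O)[C@@H](C)O)C1=O`: > 10 ug/mL
Compound 3 `C=C1[C@H](C)CCC[C@]1(C)CC/C(C)=C/CC1=C(O)C(=O)C=C(N[C@H](CO)C(=O)O)C1=O`: > 10 ug/mL

In an ADME assay on KB cells (Homo sapiens) for cytotoxicity, with a stated time of 48 h (on this read-out higher numbers stand for weaker inhibition and lower numbers for stronger inhibition), compound 1 gives > 10 ug/mL, which is a limit of the assay and not a number. Its position is therefore known only as the limit of > 10 ug/mL in this assay, at which 3 of the 3 values shown sit. Compound 4 `CC1=CCC[C@](C)(CC/C(C)=C/CC2=C(O)C(=O)C=C(N[C@H](C(=O)O)[C@H](C)O)C2=O)[C@@H]1C` is the next structure to consider, and its relation to compound 1 is simple: the two compounds have the same atoms and bonds and differ only in configuration as drawn: 1 of 5 stereo elements differ; a stereocentre at a saturated chain carbon is drawn R in compound 1 and S in compound 4. Thus a stereocentre at a saturated chain carbon is drawn R in compound 1 and S in compound 4.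

Two measured steps lie nearby, but neither changes only this stereocentre. One is a step that the two limits leave unreadable from compound 1 to compound 2, where a group of 9 heavy atoms replaces another of the same size. The other is a step that the two limits leave unreadable from compound 2 to compound 3, where 1-carboxy-2-hydroxyethyl replaces 1-carboxy-2-hydroxypropyl on an amine nitrogen. Neither step has a readable size, so they offer no measured guide to the size or direction of the change at this centre.

Among the compounds with values here, with no step to suggest otherwise, no shift beyond the usual scatter is expected, and the expected result is another limit. The estimated change is a step that the limit leaves unreadable from compound 1 to compound 4. For compound 4 the expected value is 15 ug/mL, with an estimated range from 8 ug/mL to 40 ug/mL.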

Compound 4, half-maximal inhibitory concentration: > 10 ug/mL
Compound 4 ended at the assay's limit; the forecaster's own chance of this, stated with the estimate: 85%; the middle value is on the limit's open side.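

No new step can be read between compound 1 and compound 4, since each gives only a limit and not a number: the limit of > 10 ug/mL in this assay, at which 4 of the 4 values shown sit.

The compounds shown leave open whether the stereocentre drawn R in compound 1 and S in compound 4 makes any difference in this assay, and what concentration would reach half-maximal inhibition for any of them.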